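The source may report more compounds than this note shows. Statements on the series, on what has been measured and on what is new or still open speak of the compounds shown alone.

Compound 1 `Oc1c(C(c2ccc(F)cc2)N2CCCCC2)ccc2cncnc12`: 32000 nM
Compound 2 `Cc1ccnc(NC(c2ccc3cccnc3c2O)c2c(F)cccc2Cl)c1`: 20600 nM
Compound 3 `COc1cc(C(Nc2ccc(C)cn2)c2ccc3cccnc3c2O)cc(OC)c1O`: 7400 nM

These three compounds were tested in a functional assay on U-87MG ATCC cells for inhibition, with U-87 MG (Homo sapiens) as the target, read by MTT assay, with a stated time of 72 h; a higher number here means a weaker inhibitor, a lower number a stronger inhibitor. Compound 2 gives 20600 nM, and this value cannot be told apart from that of compound 1 at 32000 nM, since the two lie within the usual scatter of repeated measurements. Compound 3, at 7400 nM, shows a lower number than compound 2, beyond that scatter, and so is the stronger inhibitor of that pair.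

The next compound, compound 4 `Cc1ccnc(NC(c2ccc3cccnc3c2O)c2c(Cl)cccc2Cl)c1`, has not yet been measured. It departs from compound 2 at a single place, with chloro in place of fluoro on an aromatic carbon, ortho to a large group and meta to a chloro group: chloro in place of fluoro on an aromatic carbon. The same difference reads 2-chloro-6-fluorophenyl to 2,6-dichlorophenyl.

Within the data shown here, no pair of measured compounds shows this swap or any other single change, so the data offer no direct guide to its effect in this assay. The best starting point is therefore compound 2 at 20600 nM, and no shift beyond the scatter is expected. The expected change is small, a 1.2-fold lower number from compound 2 to compound 4 (0.08 log units; within the scatter), and would lie within the scatter. For compound 4 the estimate is 17000 nM, with an expected range of 7500 nM to 38000 nM.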

Compound 4, half-maximal inhibitory concentration: 7200 nM
Estimate against measurement, compound 4: 2.4-fold (0.37 log units) above; the whole stated range lies above it.
By their numbers in this assay, from the lowest: compounds 4 and 3 (each within the scatter of the next); then compounds 2 and 1 (each within the scatter of the next).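

In this assay, among these compounds, this is the first comparison in the set where only one place changes, and it shows that the group on this aromatic carbon, ortho to a large group and meta to a chloro group, affects the result: chloro in place of fluoro gives a 2.9-fold lower number from compound 2 to compound 4 (0.46 log units; beyond the scatter), a clear difference even though this is a swap of one single atom for another. The change from 2-chloro-6-fluorophenyl to 2,6-dichlorophenyl leaves the counts of rings, hydrogen-bond donors and hydrogen-bond acceptors untouched, yet it still makes the second compound of this pair the stronger inhibitor. No measurement offered here explains why the number falls with this swap.

Still open, as far as these compounds go, is how other groups would behave at this same place, such as bromo, methyl, methoxy or a plain hydrogen, and whether any of them would move the number further than chloro does. Also open, from the compounds shown here alone, is whether the same swap would give a similar step on a different core, such as the core of compound 1.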